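The source may hold more compounds than are shown below. What is called first, only, known or untested is meant among the compounds shown, and "the series" means these compounds.

Measured in a functional assay on HT-29 cells (Homo sapiens); a lower number here means that less compound is needed, a higher number that more compound is needed for the effect:
- Compound 1 `CN(C)C(=O)c1ccc(-c2cc(C(=O)N[C@H]3CCCNC3)c(NC(N)=O)s2)cc1`: 320 nM
- Compound 2 `NC(=O)Nc1sc(-c2ccc(Cl)cc2)cc1C(=O)N[C@H]1CCCNC1`: 40 nM

Among the compounds with values here, of these two, compound 2 has the lower number at 40 nM, with compound 1 as its only neighbour. Compound 3 `CN(C)c1ccc(-c2cc(C(=O)N[C@H]3CCCNC3)c(NC(N)=O)s2)cc1` has not yet been measured. It carries dimethylamino in place of chloro on an aromatic carbon, para to a large group: dimethylamino in place of chloro on an aromatic carbon.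

Within the data shown here, only one measured step bears on this change, an 8.0-fold lower number from compound 1 to compound 2 (0.90 log units; beyond the scatter), with chloro in place of dimethylcarbamoyl on an aromatic carbon. Among the measured compounds shown here, no measured compound yet carries dimethylamino itself. For the measured compounds named here, compound 1, at 320 nM, is the only measured compound without the chloro, so a higher number is expected in this assay, though a smaller step than that one.

The expected change is a 3.0-fold higher number from compound 2 to compound 3 (0.48 log units; beyond the scatter). For compound 3 the estimate is 120 nM, with an expected range of 40 nM to 400 nM.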

Compound 3, half-maximal effective concentration: 90 nM
The estimate for compound 3 lay 1.3-fold (0.12 log units) above the measured number, within the range that was stated.
By their numbers in this assay, from the lowest: compound 2; then compound 3; then compound 1.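

In this assay, dimethylamino places a third group at this aromatic carbon, and its number falls between those of the other two: a 2.3-fold higher number from compound 2 to compound 3 (0.35 log units; beyond the scatter), and a 3.6-fold lower number from compound 1 to compound 3 (0.55 log units; beyond the scatter). The change shows that this carbon of the six-membered aromatic ring accepts a group without chlorine, carrying a nitrogen and a hydrogen-bond acceptor, at a smaller cost than dimethylcarbamoyl, although chloro in compound 2 still gives the lowest number of the three. No measurement at hand explains this order of the three groups.

On these data alone, whether methoxy, fluoro or a carboxylic acid at the same carbon would fall below compound 2 at 40 nM remains open. Also open, as far as these compounds go, is whether the order of these three groups would hold with a change elsewhere on the shared core.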